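Swapping the amine side chain: expected solubility of compound 4

The compounds below may be only part of what the source reports. "The series", "measured", "known", "first", "only" and "open" are said of these compounds alone.

Measured compounds:
- Compound 1, `COc1ccc2[nH]c(C(=O)N3CC(=O)N(Cc4ccccc4)[C@@H](CN4CCC(C)CC4)C3)cc2c1`: 93100 nM
- Compound 2, `O=C(c1cc2cc(C3CC3)ccc2[nH]1)N1CC(=O)N(Cc2ccccc2)[C@@H](CN2CCN(Cc3ccccc3)CC2)C1`: 12900 nM
- Compound 3, `COc1ccc2[nH]c(C(=O)N3CC(=O)N(Cc4c[nH]c5ccccc45)[C@@H](Cc4ccccc4)C3)cc2c1`: 10300 nM

Of the compounds shown here, three share a common core and have been tested in a physicochemical assay for solubility, read by spectrophotometry, in phosphate buffer, with a stated time of 2 h, at pH 7.4; a higher number here means a more soluble compound, a lower number a less soluble compound. Compound 1 gives the highest number of the three, 93100 nM. Compound 2 sits closest to it, and compound 3 is furthest away; both gaps to compound 1 are beyond the usual scatter of this assay, so compound 1 is clearly the most soluble of the three.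

Compound 4, `COc1ccc2[nH]c(C(=O)N3CC(=O)N(Cc4ccccc4)[C@@H](CN4CCN(c5ccccn5)CC4)C3)cc2c1`, has not yet been measured. It differs from compound 1 in one place: 4-(pyridin-2-yl)piperazin-1-yl in place of 4-methylpiperidin-1-yl on a saturated chain carbon bound to a saturated ring carbon. The group that leaves is small and saturated; the group that enters is larger and brings an aromatic ring. For the measured compounds named here, no pair of measured compounds that differ in exactly one place is available, so the size of the step has to be guessed. The lower values of compound 2 and compound 3 give a rough sense of where other members of this series land. A downward step in this assay is expected for compound 4, beyond the scatter, with the step from compound 1 to compound 4 estimated as a 3.7-fold lower number from compound 1 to compound 4 (0.57 log units; beyond the scatter). Compound 4 is expected to give about 25000 nM, within a range from 8000 nM to 80000 nM.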

Compound 4, solubility: 30200 nM
Estimate against measurement, compound 4: 1.2-fold (0.08 log units) below, within the range that was stated.
By their numbers in this assay, from the lowest: compounds 3 and 2 (each within the scatter of the next); then compound 4; then compound 1.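

In this assay, for the compounds shown here, compounds 1 and 4 form the first pair here that differs in one place, so the effect of this change can be read directly. Putting 4-(pyridin-2-yl)piperazin-1-yl in place of 4-methylpiperidin-1-yl on a saturated chain carbon bound to a saturated ring carbon gives a 3.1-fold lower number from compound 1 to compound 4 (0.49 log units; beyond the scatter), a modest step that is beyond the scatter. No measured evidence bears on why the number falls.

This single step changes the ring atoms, adds an aromatic ring and enlarges the group all at once, so the parts played by each remain unseparated. Morpholin-4-yl or 4-phenylpiperazin-1-yl at the same place would help to separate them, and whether the step holds on another core also remains open.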